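Aryl swap at the fused core: compound 2 to compound 3

A few compounds are considered here, and "the series" means these few. Any claim that something is new, unique, unknown or untested is made for them only; others in the source may bear on it.

Measured compounds:
compound 1 `COc1ccc(-c2cn3ccnc3c(-c3ccc4ncn(C5CCCCC5)c4c3)n2)cc1` gives 71.2% in a functional assay on OVCAR-8 cells (Homo sapiens) for inhibition, read by sulforhodamine B assay, with a stated time of 48 h, tested at 10 uM; a higher number here means more inhibition at the concentration tested (going by the name of the read-out), a lower number less inhibition
compound 2 `CC(=O)c1ccc(-c2cn3ccnc3c(-c3ccc4ncn(C5CCCCC5)c4c3)n2)cc1` gives 6.38% in this assay

Compound 2 stands lowest of the two numbers in this assay; its nearest neighbour is compound 1, whose value lies well above it. Going by the values given here, the only step between measured compounds is a number 64.8 percentage points lower from compound 1 to compound 2 (beyond the scatter), a large drop for a change of one group on the aromatic carbon.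

Compound 3 `c1csc(-c2cn3ccnc3c(-c3ccc4ncn(C5CCCCC5)c4c3)n2)c1` is not yet measured. It differs from compound 2 by thiophen-2-yl in place of 4-acetylphenyl on an aromatic carbon. Among the compounds with values here, the single measured step bears on it only by showing that this position is sensitive: the loss from compound 1 to compound 2 was large, so replacing the 4-acetylphenyl group can move the number a long way. Thiophen-2-yl resembles neither the methoxy nor the acetyl case, so the direction is uncertain, but a rise from the low value of compound 2 is expected, of size a number 33.6 percentage points higher from compound 2 to compound 3 (beyond the scatter). For compound 3 the estimate in this assay is 40%, within 10% to 75%.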

Compound 3, a percentage reported as inhibition, at one concentration (the size of the read-out at that concentration, not a potency): 9.34%
Estimate against measurement, compound 3: 30.7 percentage points above; the whole stated range lies above it.
By their numbers in this assay, from the lowest: compounds 2 and 3 (each within the scatter of the next); then compound 1.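

In this assay, at this aromatic carbon, thiophen-2-yl in place of 4-acetylphenyl gives a number 3 percentage points higher from compound 2 to compound 3 (within the scatter) and so leaves the number where compound 2 had it, even though the groups differ in ring size and heavy-atom count. Thiophen-2-yl in place of 4-methoxyphenyl gives a number 61.9 percentage points lower from compound 1 to compound 3 (beyond the scatter) and so the large loss is no longer tied to the acetyl group alone: of the three compounds, only compound 1 stands apart, with the 4-methoxyphenyl group. No measurement at hand accounts for this.

The compounds shown leave open whether the methoxy group needs the phenyl ring, which a methoxy-bearing thiophene would test. They also leave open whether a 4-hydroxyphenyl, 4-aminophenyl or 4-ethoxyphenyl group at this carbon would stay near compound 1 or fall to the level of compound 2 and compound 3.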